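Replacing methyl with methoxycarbonyl on compound 1

The source may report more compounds than this note shows. Statements on the series, on what has been measured and on what is new or still open speak of the compounds shown alone.

Among the compounds with values here, in a functional assay on MCF7 cells (Homo sapiens) for inhibition, read by radiometric assay and XTT assay (a higher number here means a weaker inhibitor, a lower number a stronger inhibitor), compound 1 (`CCCCCCCC[C@@]1(C)SC(O)=C(C)C1=O`) gives 48 ug/mL and sits at the weaker end of the three compounds measured so far. Compound 3 (`C=CCOC(=O)OC1=CC(=O)S[C@]1(C)CCCCCCCC`) gives 37.3 ug/mL and cannot be told apart from compound 1 within the scatter. Compound 2 (`C#CCOC1=CC(=O)S[C@]1(C)CCCCCC`) gives 8.9 ug/mL and stands clearly apart from both as the stronger inhibitor.

Compound 4 (`CCCCCCCC[C@@]1(C)SC(O)=C(C(=O)OC)C1=O`) has not yet been measured. It keeps the core of compound 1 but carries methoxycarbonyl in place of methyl on a double-bonded ring carbon, next to the ring atom that bears a hydroxy group (methoxycarbonyl in place of methyl on a double-bonded ring carbon). Within the data shown here, no two measured compounds differ in one place only, so the data hold no direct measure of this change. The expectation in this assay is therefore for no step beyond the scatter in either direction, with the starting point set by compound 1 at 48 ug/mL and a wide margin left open. The expected step of a 1.2-fold lower number from compound 1 to compound 4 (0.08 log units; within the scatter) is accordingly small. For compound 4 the estimated value is 40 ug/mL with an expected range from 15 ug/mL to 100 ug/mL in this measurement.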

Compound 4, half-maximal inhibitory concentration: 47.2 ug/mL
For compound 4 the middle estimate is 1.2-fold (0.07 log units) below the measured one; the measured number falls inside the stated range.
By their numbers in this assay, from the lowest: compound 2; then compounds 3, 4 and 1 (each within the scatter of the next).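

Methoxycarbonyl in place of methyl on a double-bonded ring carbon gives, in this assay, a 1.0-fold lower number from compound 1 to compound 4 (0.01 log units; within the scatter) and this is the first change in a single place that can be read in this set. The earlier compounds shown here differ from one another in more than one place, so they could say nothing about this ring carbon on its own. Here the position takes a larger group that brings hydrogen-bond acceptors, which methyl does not have, and the number stays within the scatter, a finding that rests on this one pair and this one core; no independent measurement bears on why the number stays put.

Going by these compounds, whether other groups on this ring carbon, such as a carboxylic acid or an amide, would also leave the number within the scatter remains open. The clear gap between compound 2 and the others also remains unexplained, since compound 2 differs from each of them in more than one place and no single change can be read from it.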